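Swapping one aryl group on a shared enone core

The source may report more compounds than this note shows. Statements on the series, on what has been measured and on what is new or still open speak of the compounds shown alone.

Measured so far in a functional assay on A549 cells (Homo sapiens) for cytotoxicity, read by MTT assay, with a stated time of 72 h; on this read-out lower numbers stand for stronger inhibition and higher numbers for weaker inhibition:
compound 1, `COc1cccc(/C=C2\CCC/C(=C\c3cc(OC)c(OC)c(OC)c3)C2=O)c1OC`, gives 5900 nM
compound 2, `COc1cc(/C=C2\CCC/C(=C\c3cccc(OC)c3OC)C2=O)ccc1O`, gives > 20000 nM
compound 3, `COc1ccc(/C=C2\CCC/C(=C\c3ccccc3Cl)C2=O)cc1OC`, gives > 20000 nM

Compound 3 gives only a limit in this assay, > 20000 nM, not a number. Its position among the values is the limit of > 20000 nM in this assay, at which 2 of the 3 values shown sit. Compound 1 is the only one of the three that gives a number at all.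

Compound 4, `COc1ccc(/C=C2\CCC/C(=C\c3ccc(O)c(Cl)c3)C2=O)cc1OC`, differs from compound 3 in one place: 3-chloro-4-hydroxyphenyl in place of 2-chlorophenyl on a double-bonded chain carbon bound to a double-bonded ring carbon. Among the measured compounds shown here, no measured pair differs in a single place, so no measured step shows how such a change plays out on this core. Compound 2 also carries a hydroxy-bearing aryl group and gives only a limit, > 20000 nM.

The expected step is a number no higher from compound 3 to compound 4 (the limit leaves the size open), that is, no change beyond the usual scatter is expected. Compound 4 is therefore estimated at about 20000 nM, with a likely range from 7000 nM to 50000 nM, and it may well again come out only as a limit.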

Compound 4, half-maximal inhibitory concentration: > 20000 nM
Compound 4: only a limit was reported; the forecaster's own chance of this, stated with the estimate: 55%; the middle value sits exactly at the limit.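

Compound 3 and compound 4 both give only a limit and not a number, so no step between them can be read: the limit of > 20000 nM in this assay, at which 3 of the 4 values shown sit.

The compounds shown leave open whether 3-chloro-4-hydroxyphenyl in place of 2-chlorophenyl changes the result on the shared core at all, and in which direction.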